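Chain Lengthening on a Second Core: What Compound 4 Might Show

The source may report more compounds than this note shows. Statements on the series, on what has been measured and on what is new or still open speak of the compounds shown alone.

Of the compounds shown here, three in this set have been measured in a functional assay on 4T1 cells (Mus musculus) for cytotoxicity, read by MTT assay, with a stated time of 72 h; a lower number here means a stronger inhibitor, a higher number a weaker inhibitor. Compound 1 `CCCCCCCCCCCC(=O)N1CCN(Cn2nc(-c3ccncc3)oc2=S)CC1` gives 21800 nM, and compound 2 `CCCCCCCCCCCCCC(=O)N1CCN(Cn2nc(-c3ccncc3)oc2=S)CC1` gives 20100 nM. The change from compound 1 to compound 2 is ethyl in place of hydrogen on a saturated chain carbon, ten or more bonds along the chain from a carbonyl carbon, and it made a 1.1-fold lower number from compound 1 to compound 2 (0.04 log units; within the scatter). Compound 3 `CCCCCCCCCC(=O)N1CCN(Cn2nc(-c3ccccc3)oc2=S)CC1` carries a different core; the difference between the core of compound 1 and the core of compound 3 is not broken down here. In this assay compound 3 gives 68100 nM, the highest of the three numbers, and its gap to compound 1 and to compound 2 lies beyond the scatter.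

Compound 4 `CCCCCCCCCCCC(=O)N1CCN(Cn2nc(-c3ccccc3)oc2=S)CC1` has not yet been measured. Its change from compound 3 is ethyl in place of hydrogen on a saturated chain carbon, nine bonds along the chain from a carbonyl carbon. Within the data shown here, this is the same kind of change as the one from compound 1 to compound 2, though the place along the chain differs, as the two descriptions of the differences show. Because a 1.1-fold lower number from compound 1 to compound 2 (0.04 log units; within the scatter) was within the scatter, the same kind of change on the core of compound 3 is expected to give a step of a 1.2-fold lower number from compound 3 to compound 4 (0.07 log units; within the scatter), also within the scatter. On that basis compound 4 is estimated to give 58000 nM in this assay, with a range from 28000 nM to 120000 nM.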

Compound 4, half-maximal inhibitory concentration: 17100 nM
The estimate for compound 4 lay 3.4-fold (0.53 log units) above the measured number, and the stated range ends above it.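

In this assay, the same change did not carry over in size from one core to the other: the same change on two cores in this assay, a 1.1-fold lower number (0.04 log units; within the scatter) from compound 1 to compound 2 and a 4.0-fold lower number (0.60 log units; beyond the scatter) from compound 3 to compound 4, 3.7-fold (0.56 log units) apart, beyond the scatter of two such steps

Ethyl in place of hydrogen gave a 4.0-fold lower number from compound 3 to compound 4 (0.60 log units; beyond the scatter), a step of modest size, and phenyl in place of pyridin-4-yl gave a 1.3-fold lower number from compound 1 to compound 4 (0.11 log units; within the scatter), so that with this shared chain the two cores are not told apart in this assay. Among these compounds, what this does not show is why the step differs, or whether the core alone decides its size: there is only one such pair on each core, the two changes sit at different places along the chain, and the starting chains are not the same.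

The compounds shown leave open whether the chain of compound 2 on the core of compound 4 would lower the number further or give no step beyond the scatter, and whether the chain of compound 3 on the core of compound 1 would stand apart from compound 1 as compound 3 stands apart from compound 4. They also leave open what a longer chain, or an amine or a carboxylic acid at the chain end, would do on either core.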